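Removing the methoxy from the most potent compound

This account rests on a few compounds, and the source may have more. Where it says the series, first, only, none or still open, it means among the compounds named here.

Values measured in a functional assay on HeLa cells (Homo sapiens) for cytotoxicity, read by MTT assay, with a stated time of 72 h (a higher number here means a weaker inhibitor, a lower number a stronger inhibitor), follow

- compound 1 `COC(=O)c1sc2cc(OC)ccc2c1Nc1cc(OC)c(OC)c(OC)c1` gives 0.28 nM
- compound 2 `CCOC(=O)c1sc2cccc(C)c2c1Nc1cc(OC)c(OC)c(OC)c1` gives 2520 nM
- compound 3 `COC(=O)c1sc2ncccc2c1Nc1cc(OC)c(OC)c(OC)c1` gives 342 nM

Compound 1 has the lowest number of the three, and both gaps to the others lie far beyond the scatter. Compound 4 `COC(=O)c1sc2ccccc2c1Nc1cc(OC)c(OC)c(OC)c1` has hydrogen in place of methoxy on an aromatic carbon. Among the measured compounds shown here, no measured pair isolates this change. Neither compound 3 (342 nM) nor compound 2 (2520 nM) carries that methoxy, though both differ from compound 4 elsewhere as well. A large rise in this assay is therefore expected, beyond the scatter: the estimated step is an 890-fold higher number from compound 1 to compound 4 (2.95 log units; beyond the scatter). For compound 4 the expected value is 250 nM, within an estimated range from 30 nM to 2000 nM.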

Compound 4, half-maximal inhibitory concentration: 427 nM
Compound 4: middle estimate off by 1.7-fold (0.23 log units), on the low side, within the range that was stated.
By their numbers in this assay, from the lowest: compound 1; then compounds 3 and 4 (each within the scatter of the next); then compound 2.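

In this assay, among the compounds shown here, the replacement of methoxy by hydrogen on this aromatic carbon gives a 1500-fold higher number from compound 1 to compound 4 (3.18 log units; beyond the scatter) and is the first change isolated at a single place. With the rest of the core of compound 1 unchanged, the sub-nanomolar potency in this pair depends on that methoxy. Nothing available explains the size of this step.

Still open, as far as these compounds go, is whether a hydroxyl, an amine or a longer ether such as ethoxy on this carbon would retain the potency of compound 1. The compounds shown also leave open whether fluorine could stand in for the methoxy.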